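This account rests on a few compounds, and the source may have more. Where it says the series, first, only, none or still open, it means among the compounds named here.

Compound 1 `CCCCc1nn(-c2nc(N)c3c(n2)NC(=O)C3(C)C)c2ccc(Cl)cc12` gives 47000 nM in an assay on CHO cells for activation of soluble guanylate cyclase alpha1/beta1 complex (Homo sapiens), read by cGMP accumulation; on this read-out higher numbers stand for an effect only at larger amounts of compound and lower numbers for an effect already at smaller amounts.
Compound 2 `CC1(C)C(=O)Nc2nc(-n3nc(Cc4c(F)ccc(F)c4F)c4cc(Cl)ccc43)nc(N)c21` gives 7300 nM in this assay.

Of the two measured compounds, compound 2 stands at the lower number, and compound 1 at the higher one, so compound 2 is the one that acts at smaller amounts. Among the measured compounds shown here, the step between them, a 6.4-fold lower number from compound 1 to compound 2 (0.81 log units; beyond the scatter), is the only measured step, and it describes the effect of putting an aromatic ring on the chain carbon in place of a plain alkyl chain.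

Compound 3 `CCCCCc1nn(-c2nc(N)c3c(n2)NC(=O)C3(C)C)c2ccc(Cl)cc12` has not yet been measured. It differs from compound 2 by butyl in place of 2,3,6-trifluorophenyl on a saturated chain carbon bound to an aromatic carbon. That is the reverse of the measured step: the aromatic ring leaves and an alkyl chain enters, giving a pentyl chain on the shared core, where compound 1 carries butyl. Since compound 1 and compound 3 differ only in the length of that chain, compound 3 is expected to lie close to compound 1, and the step of a 5.5-fold higher number from compound 2 to compound 3 (0.74 log units; beyond the scatter) is therefore expected to go upward, roughly undoing the measured step. Compound 3 is estimated at 40000 nM, within 12000 nM to 120000 nM.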

Compound 3, half-maximal effective concentration: 90000 nM
For compound 3 the middle estimate is 2.3-fold (0.35 log units) below the measured one, and the stated range covers the measured number.
By their numbers in this assay, from the lowest: compound 2; then compounds 1 and 3 (each within the scatter of the next).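

Reversing the earlier change gives a 12-fold higher number from compound 2 to compound 3 (1.09 log units; beyond the scatter) in this assay, so the lower number of compound 2 now stands against two different alkyl chains rather than one, and the 2,3,6-trifluorobenzyl group stays ahead of both butyl and pentyl at this place. Chain length, by contrast, makes little difference here: turning the butyl chain into the pentyl chain, with methyl in place of hydrogen on a saturated chain carbon, gives a 1.9-fold higher number from compound 1 to compound 3 (0.28 log units; within the scatter), so these two chains cannot be told apart on this read-out. Nothing available explains why the aromatic ring and the alkyl chains differ in this way.

The only aromatic group shown carries fluorine atoms, so it remains open whether the ring alone or the ring together with its fluorines goes with the lower number, a question that a plain benzyl group would help to settle. On these data alone, it is also open how a different kind of group at this place would behave, such as a chain ending in an amine or a carboxylic acid, or a much longer chain.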